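Halogen swap on the shared core: iodo to fluoro

This account rests on a few compounds, and the source may have more. Where it says the series, first, only, none or still open, it means among the compounds named here.

Values in a functional assay on MCF7 cells (Homo sapiens) for inhibition, with a stated time of 48 h; a higher number here means a weaker inhibitor, a lower number a stronger inhibitor:
- compound 1 `COc1cc(Sc2c[nH]c3ccc(Br)cc23)cc(OC)c1OC`: 43 nM
- compound 2 `COc1cc(Sc2c[nH]c3ccc(I)cc23)cc(OC)c1OC`: 68 nM

Compound 2, at 68 nM, stands within the scatter of compound 1, so the two cannot be ranked. The next compound is compound 3 `COc1cc(Sc2c[nH]c3ccc(F)cc23)cc(OC)c1OC`, and the change is fluoro in place of iodo on an aromatic carbon. Going by the values given here, only one measured step bears on it: a 1.6-fold higher number from compound 1 to compound 2 (0.20 log units; within the scatter), a swap of iodo for bromo on an aromatic carbon. Among the compounds with values here, that step stays within the scatter, but it covers only two halogens, and no fluoro compound has been measured yet, so the read-across is weak. No step beyond the scatter is expected in this assay, and no direction is favoured, though the range is kept wide. The expected step is a 1.0-fold higher number from compound 2 to compound 3 (0.01 log units; within the scatter). For compound 3 the estimated value is 70 nM, with an expected range from 25 nM to 220 nM.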

Compound 3, half-maximal inhibitory concentration: 160 nM
The estimate for compound 3 lay 2.3-fold (0.36 log units) below the measured number; the range from low to high includes it.
By their numbers in this assay, from the lowest: compounds 1 and 2 (each within the scatter of the next); then compound 3.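

In this assay, going by these compounds alone, this position on the shared core proves sensitive to the choice of halogen: fluoro in place of iodo gives a 2.4-fold higher number from compound 2 to compound 3 (0.37 log units; beyond the scatter) and fluoro in place of bromo gives a 3.7-fold higher number from compound 1 to compound 3 (0.57 log units; beyond the scatter) as the first steps beyond the scatter. Compound 3 therefore carries the higher number against both heavier halogens, while compounds 1 and 2 remain unranked, so the series separates fluoro from bromo and iodo but not bromo from iodo. No measured evidence accounts for this difference.

From the compounds shown here alone, what chloro, methoxy, nitrile or an amine would give at this position remains open. Also open, going by these compounds, is whether the fluoro step would keep its size with the trimethoxy-substituted part of the shared core changed.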